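The source may report more compounds than this note shows. Statements on the series, on what has been measured and on what is new or still open speak of the compounds shown alone.

Measured so far:
Compound 1 `Cc1nnc(SCC(=O)c2ccc(Cl)cc2)n1N1C(=O)c2ccccc2C1=O` — in a functional assay on HepG2 cells (Homo sapiens) for cytotoxicity, read by MTT assay, with a stated time of 48 h (on this read-out higher numbers stand for weaker inhibition and lower numbers for stronger inhibition), compound 1 gives > 200000 nM, which is a limit of the assay rather than a number.
Compound 2 `Cc1nnc(SCC(=O)c2ccccc2)n1N1C(=O)c2ccccc2C1=O` — in this assay compound 2 gives > 200000 nM, again a limit.
Compound 3 `C#CCSc1nnc(-c2cc(OC)c(OC)c(OC)c2)n1N1C(=O)c2ccccc2C1=O` — in this assay compound 3 gives > 200000 nM, also a limit.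

Compound 3 therefore stands where every measured compound stands: at the limit of > 200000 nM in this assay, at which 3 of the 3 values shown sit, with no number of its own to set against the others. Within the data shown here, the single step between measured compounds, hydrogen in place of chloro on an aromatic carbon, is a step that the two limits leave unreadable from compound 1 to compound 2; it offers no guide to size or direction. The unmeasured compound 4 `COc1cc(-c2nnc(SCC(=O)c3ccc(F)c(F)c3)n2N2C(=O)c3ccccc3C2=O)cc(OC)c1OC` differs from compound 3 by (3,4-difluorophenyl)carbonyl in place of ethynyl on a saturated chain carbon bound to a sulfur. Among the measured compounds shown here, no measured step touches a saturated chain carbon bound to a sulfur, so nothing measured bears directly on this change; all that the three measured compounds share is that none reached a readable number. The step from compound 3 to compound 4 is thus expected to be a number no higher from compound 3 to compound 4 (the limit leaves the size open), no visible movement beyond the scatter. Compound 4 is estimated to give 200000 nM in this assay, within a range from 50000 nM to 600000 nM, and most probably reported once more only as a limit.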

Compound 4, half-maximal inhibitory concentration: > 200000 nM
Compound 4: a limit, no number; the forecaster's own chance of this, stated with the estimate: 80%; the middle value lies on the limit itself.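

In this assay compound 4 gives > 200000 nM, which is a limit and not a number. Compound 3 also has only a limit, so no step can be read between compound 3 and compound 4. The same holds across the series: the limit of > 200000 nM in this assay, at which 4 of the 4 values shown sit.

The compounds shown leave open how they differ in strength and which change, if any, would give a readable number.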